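Nitro-to-fluoro step across two related cores

The source may hold more compounds than are shown below. What is called first, only, known or untested is meant among the compounds shown, and "the series" means these compounds.

Compound 1 `O=C1OC(c2ccc(Cl)cc2)=C/C1=C\c1ccc([N+](=O)[O-])cc1` and compound 2 `O=C1OC(c2ccc(Cl)cc2)=C/C1=C\c1ccc(F)cc1` share one core; compound 3 `O=C1/C(=C/c2ccc([N+](=O)[O-])cc2)C=C(c2ccc(Cl)cc2)N1Cc1ccccc1` and compound 4 `O=C1/C(=C/c2ccc(F)cc2)C=C(c2ccc(Cl)cc2)N1Cc1ccccc1` share another, and the difference between the two cores is not broken down here. In a functional assay on the whole organism (strain Wistar) for inhibition, with Rattus norvegicus as the target, with stated times of 30 min and 2 h, at a dose of 20 mg/kg by the oral route (a lower number here means less inhibition, a higher number more inhibition at the dose given (going by the name of the read-out)), compound 1 gives 4% and compound 2 gives 41.3%. The change between them is fluoro in place of nitro on an aromatic carbon and it made a number 37.3 percentage points higher from compound 1 to compound 2 (beyond the scatter). In this assay compound 3 gives 12%, a number within the scatter of that for compound 1. Compound 4 carries the same change on the other core, (fluoro in place of nitro on an aromatic carbon), fluoro in place of nitro on an aromatic carbon. Among the measured compounds shown here, a step of like direction and roughly like size is expected, a number 28 percentage points higher from compound 3 to compound 4 (beyond the scatter), because the one measured instance gave a number 37.3 percentage points higher from compound 1 to compound 2 (beyond the scatter), though a single instance leaves the size uncertain. Compound 4 is therefore estimated at 40%, with a range from 20% to 60%.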

Compound 4, a percentage reported as inhibition, in the whole organism at one dose (the size of the read-out at that dose, not a potency): 58.7%
Compound 4: the middle estimate sits 18.7 percentage points below what was measured; measured number inside the range.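

In this assay, fluoro in place of nitro on an aromatic carbon gives a number 46.7 percentage points higher from compound 3 to compound 4 (beyond the scatter). The change carries from one core to the other, in direction and in size: the same change on two cores in this assay, a number 37.3 percentage points higher (beyond the scatter) from compound 1 to compound 2 and a number 46.7 percentage points higher (beyond the scatter) from compound 3 to compound 4, 9.4 percentage points apart, within the scatter of two such steps

Among the compounds shown here, this rests on only two cores and one pair of groups, so it sets no general rule for the series and gives no reason for the step. It also leaves the difference between the two cores unresolved.

Open, on these data alone, is how an amine, a carboxylic acid or a methoxy group would read in this assay on the same aromatic carbon, in place of fluoro. Also open, as far as these compounds go, is whether the step holds on a third core.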